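This account rests on a few compounds, and the source may have more. Where it says the series, first, only, none or still open, it means among the compounds named here.

Working notes on the series. Compound 1 `CC1CCCCC1N(C(=O)c1cc(C2CC2)on1)C1CCCCC1` and compound 2 `O=C(c1cc(-c2ccccc2)on1)N(C1CCCCC1)C1CCCCC1` share the core and were both tested in an assay on isolated protein for agonist activity at sphingosine 1-phosphate receptor 2 (Homo sapiens); on this read-out lower numbers stand for an effect already at smaller amounts and higher numbers for an effect only at larger amounts of compound. In this assay compound 1 gives only a limit rather than a number, > 50000 nM. In this assay compound 2 likewise gives a limit, not a number, > 50000 nM. For the measured compounds named here, compound 2 therefore stands at the limit where both values shown so far sit (the limit of > 50000 nM in this assay, at which 2 of the 2 values shown sit), and no step between measured compounds can be read from the data. Compound 3 `COc1ccc(-c2cc(C(=O)N(C3CCCCC3)C3CCCCC3)no2)cc1` is the next compound: methoxy in place of hydrogen on an aromatic carbon, so that phenyl becomes 4-methoxyphenyl. Going by the values given here, with both measured compounds at the limit there is no step to extrapolate from. The expectation is that this assay again shows no effect beyond the scatter, with the step that the limit leaves unreadable from compound 2 to compound 3 expected to be none beyond the scatter. Compound 3 is estimated at 80000 nM, within 20000 nM to 300000 nM, and most likely reported again only as a limit.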

Compound 3, half-maximal effective concentration: > 50000 nM
Compound 3 was reported as a limit (the forecaster's own chance of this, stated with the estimate: 85%); the middle value does not contradict the limit.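

No step between compound 2 and compound 3 can be read in this assay, since each is reported only as a limit: the limit of > 50000 nM in this assay, at which 3 of the 3 values shown sit.

The compounds shown leave open whether methoxy in place of hydrogen on the phenyl changes anything in this assay, and whether any change to the shared core gives a numerical value.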